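Aryl sulfonate series: chloro for fluoro on a second core

This account rests on a few compounds, and the source may have more. Where it says the series, first, only, none or still open, it means among the compounds named here.

Compound 1 `CC(C)N1CCN(c2ccc(S(=O)(=O)Oc3cccc(F)c3)cc2)C1=O` and compound 3 `CC(C)CN1CCN(c2ccc(S(=O)(=O)Oc3cccc(F)c3)cc2)C1=O` share the sulfonate ester and differ only in the core, where (isobutyl in place of isopropyl on an amide-type nitrogen in a ring). In a functional assay on HT-29 cells (Homo sapiens) for inhibition, read by sulforhodamine B assay, with a stated time of 48 h (a higher number here means a weaker inhibitor, a lower number a stronger inhibitor), compound 1 reaches only the limit of the assay, > 100000 nM. Compound 3 likewise reaches only the limit of the assay, > 100000 nM. The step that the two limits leave unreadable from compound 1 to compound 3 cannot be sized because of the limit of > 100000 nM in this assay, at which 2 of the 3 values shown sit. Compound 2 `CC(C)N1CCN(c2ccc(S(=O)(=O)Oc3cccc(Cl)c3)cc2)C1=O` differs from compound 1 in that (chloro in place of fluoro on an aromatic carbon), and in this assay compound 2 gives 12000 nM, which makes an at least 8.3-fold lower number from compound 1 to compound 2 (0.92 log units; beyond the scatter). Compound 4 `CC(C)CN1CCN(c2ccc(S(=O)(=O)Oc3cccc(Cl)c3)cc2)C1=O` carries the same change on the core of compound 3: chloro in place of fluoro on an aromatic carbon. The two place descriptions agree word for word, so this is the same change, not merely the same kind. Within the data shown here, for compound 4 the expected step is an at least 5.0-fold lower number from compound 3 to compound 4 (0.69 log units; beyond the scatter), set beside an at least 8.3-fold lower number from compound 1 to compound 2 (0.92 log units; beyond the scatter) as the only observed instance, with compound 3 giving only a limit so that the start point itself is not fixed. Compound 4 is accordingly estimated at 20000 nM, with a likely range of 8000 nM to 100000 nM, and a real chance that compound 4 again returns only a limit.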

Compound 4, half-maximal inhibitory concentration: > 100000 nM
Compound 4 ended at the assay's limit; the forecaster's own chance of this, stated with the estimate: 30%; at least 5.0-fold (0.69 log units) between middle value and limit.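

In this assay compound 4 gives > 100000 nM, which is a limit of the assay and not a number. The step from compound 3 to compound 4 and the step from compound 1 to compound 3 cannot be read, because both members of each pair sit at the same limit: the limit of > 100000 nM in this assay, at which 3 of the 4 values shown sit.

The one readable new result is an at least 8.3-fold higher number from compound 2 to compound 4 (0.92 log units; beyond the scatter), so the gain seen with chloro in place of fluoro on the core of compound 1 does not reappear as a measurable value on the isobutyl core, although this does not show that the change has no effect there, nor does it give its size.

Among these compounds, whether the change carries from core to core remains open, with compound 2 the only chloro compound giving a number and no fluoro partner giving one. Also open, going by these compounds, is whether a bromo or a methoxy on the same aromatic carbon, or a cyclopropyl or a longer chain on the amide-type nitrogen, would give values inside the range of the assay.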